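A few compounds are considered here, and "the series" means these few. Any claim that something is new, unique, unknown or untested is made for them only; others in the source may bear on it.

- compound 1 `CN1CCN(CCCCn2c3c(c4ccccc42)C(=O)c2c[n+]([O-])c4ccccc4c2C3=O)CC1`: 30 nM
- compound 2 `O=C1c2c[n+]([O-])c3ccccc3c2C(=O)c2c1c1ccccc1n2CCN1CCCC1`: 430 nM
- compound 3 `CN1CCN(CCCn2c3c(c4ccccc42)C(=O)c2c[n+]([O-])c4ccccc4c2C3=O)CC1`: 470 nM

All three values come from a functional assay on A-375 cells (Homo sapiens) for cytotoxicity, read by MTT assay, with a stated time of 72 h (on this read-out higher numbers stand for weaker inhibition and lower numbers for stronger inhibition), where the compounds share one core. Compound 3 stands well above compound 1 on these numbers: the step of a 16-fold higher number from compound 1 to compound 3 (1.19 log units; beyond the scatter) is large. Compound 3 cannot be told apart from compound 2, as the step of a 1.1-fold higher number from compound 2 to compound 3 (0.04 log units; within the scatter) stays within the scatter.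

Compound 4 `CN1CCN(CCCCCn2c3c(c4ccccc42)C(=O)c2c[n+]([O-])c4ccccc4c2C3=O)CC1` differs from compound 3 on a saturated chain carbon, three bonds along the chain from an aromatic nitrogen (2-(4-methylpiperazin-1-yl)ethyl in place of 4-methylpiperazin-1-yl on a saturated chain carbon, three bonds along the chain from an aromatic nitrogen). Cut one bond further out, this is 3-(4-methylpiperazin-1-yl)propyl changing to 5-(4-methylpiperazin-1-yl)pentyl.

The most relevant evidence is compound 1, which carries 4-(4-methylpiperazin-1-yl)butyl and differs from compound 3 by the large step given above. The step of a 14-fold higher number from compound 1 to compound 2 (1.16 log units; beyond the scatter) is similar in size but also swaps the ring, so it bears only loosely. On these data alone, no pentyl chain has been measured, so whether the trend continues past butyl is unknown. A clear fall in the number is therefore expected in this assay, though probably not beyond the level of compound 1. The expected change is a 6.7-fold lower number from compound 3 to compound 4 (0.83 log units; beyond the scatter). For compound 4 the estimate is 70 nM, with an expected range from 15 nM to 320 nM.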

Compound 4, half-maximal inhibitory concentration: 1710 nM
Beside the measured number, compound 4's estimate is 24-fold (1.39 log units) below it, and the stated range ends below it.
By their numbers in this assay, from the lowest: compound 1; then compounds 2 and 3 (each within the scatter of the next); then compound 4.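

In this assay, lengthening 3-(4-methylpiperazin-1-yl)propyl to 5-(4-methylpiperazin-1-yl)pentyl weakens the effect on the cells rather than strengthening it, with a 3.6-fold higher number from compound 3 to compound 4 (0.56 log units; beyond the scatter), and the loss measured against the butyl chain is much larger, with a 57-fold higher number from compound 1 to compound 4 (1.76 log units; beyond the scatter). Across these three chains ending in 4-methylpiperazin-1-yl, the number therefore does not move in one direction with length: 4-(4-methylpiperazin-1-yl)butyl gives the lowest number, and both the shorter and the longer chain give higher ones. The pentyl chain also falls behind the shorter chain ending in pyrrolidin-1-yl, with a 4.0-fold higher number from compound 2 to compound 4 (0.60 log units; beyond the scatter), though that step changes both the chain and the ring, and no measurement available here accounts for any of these differences.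

The compounds shown leave open whether the low number belongs to the butyl chain itself or to its pairing with 4-methylpiperazin-1-yl, a question that a butyl chain ending in pyrrolidin-1-yl or morpholin-4-yl would address. They also leave open how a hexyl chain ending in 4-methylpiperazin-1-yl would compare with the pentyl chain.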